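Phenyl in Place of Pyridin-4-yl: A Forecast

This account rests on a few compounds, and the source may have more. Where it says the series, first, only, none or still open, it means among the compounds named here.

Going by the values given here, compound 3 `N#Cc1ccc(NC(=O)c2ccc(-c3ccncc3)cc2O)cc1` gives 7090 nM in a functional assay on HL-60 cells (Homo sapiens) for cytotoxicity, read by luminescence and CellTiter-Glo, with a stated time of 3 days (a lower number here means a stronger inhibitor, a higher number a weaker inhibitor), the highest of the three numbers so far. Compound 1 `N#Cc1ccc(NC(=O)c2ccc(-c3cccnc3)cc2O)cc1` gives 6660 nM, and the step of a 1.1-fold higher number from compound 1 to compound 3 (0.03 log units; within the scatter) lies within the scatter. Among the compounds with values here, compound 2 `N#Cc1ccc(NC(=O)c2cc(Br)c(-c3ccccc3)cc2O)cc1` gives 700 nM, a much lower number, but it carries a bromo group as well, so no single step in this set isolates its phenyl. Compound 4 `N#Cc1ccc(NC(=O)c2ccc(-c3ccccc3)cc2O)cc1` arises from compound 3 by one change: phenyl in place of pyridin-4-yl on an aromatic carbon. Within the data shown here, no measured step bears directly on this change; compound 2 only shows that a phenyl-bearing analog can score low. Compound 4 is therefore expected near 2500 nM, within 700 nM to 8000 nM. The expected step of a 2.8-fold lower number from compound 3 to compound 4 (0.45 log units; beyond the scatter) thus leans toward a lower number, with wide uncertainty.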

Compound 4, half-maximal inhibitory concentration: 700 nM
Estimate against measurement, compound 4: 3.6-fold (0.55 log units) above; the measured number falls inside the stated range.
By their numbers in this assay, from the lowest: compounds 2 and 4 (each within the scatter of the next); then compounds 1 and 3 (each within the scatter of the next).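

In this assay, phenyl at this position stands clearly apart from both pyridinyl groups (a 10-fold lower number from compound 3 to compound 4 (1.01 log units; beyond the scatter)) and (a 9.5-fold lower number from compound 1 to compound 4 (0.98 log units; beyond the scatter)), although those two pyridinyl groups could not be told apart. Removing the bromo group leaves the number unmoved (no change at the digits printed from compound 2 to compound 4 (within the scatter)), so compound 4 matches compound 2 without it. Nothing available explains why the ring nitrogen costs so much here. As far as these compounds go, whether an amine or a carboxylic acid on the phenyl ring would keep this low number remains open.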